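A few compounds are considered here, and "the series" means these few. Any claim that something is new, unique, unknown or untested is made for them only; others in the source may bear on it.

Working notes on the series. In a functional assay on HEK293 cells for antagonist activity at P2X purinoceptor 7 (Homo sapiens), read by fluorescence, with a stated time of 2 h (on this read-out lower numbers stand for stronger inhibition and higher numbers for weaker inhibition), compound 1 `O=C(CCc1ccccc1)NNc1c(Cl)cccc1Cl` gives 1400 nM, compound 2 `O=C(CCCc1ccccc1)NNc1c(Cl)cncc1Cl` gives 770 nM, and compound 3 `O=C(CCCCc1ccccc1)NNc1c(Cl)cncc1Cl` gives 1200 nM. Of the three numbers, that of compound 3 lies within the scatter of both others, so no order among them can be read from this assay. Among the compounds with values here, the one step within the set that alters the chain alone, a 1.6-fold higher number from compound 2 to compound 3 (0.19 log units; within the scatter), is the same kind of change as the one now in question, only one bond closer to the carbonyl carbon.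

Compound 4 `O=C(CCCCCc1ccccc1)NNc1c(Cl)cncc1Cl` differs from compound 3 by benzyl in place of phenyl on a saturated chain carbon, four bonds along the chain from a carbonyl carbon. Within the data shown here, the single measured step of this kind, a 1.6-fold higher number from compound 2 to compound 3 (0.19 log units; within the scatter), did not move the number beyond the scatter, so for this assay the expected step of a 1.3-fold higher number from compound 3 to compound 4 (0.10 log units; within the scatter) is again small, without a direction that can be trusted, and no more than a slight drift toward a higher number is expected. On that basis compound 4 is estimated at 1500 nM, with a range from 700 nM to 3500 nM.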

Compound 4, half-maximal inhibitory concentration: 1900 nM
Beside the measured number, compound 4's estimate is 1.3-fold (0.10 log units) below it; the range from low to high includes it.
By their numbers in this assay, from the lowest: compounds 2, 3, 1 and 4 (each within the scatter of the next, the first and the last beyond it).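

In this assay, benzyl in place of phenyl on a saturated chain carbon, four bonds along the chain from a carbonyl carbon, gives a 1.6-fold higher number from compound 3 to compound 4 (0.20 log units; within the scatter), so this single change, like the one a bond closer to the carbonyl carbon, sets no order on its own. Taken together, however, the two changes separate the ends of the chain series: compound 2 at 770 nM and compound 4 at 1900 nM lie beyond the scatter of each other, with the higher number on the longer chain. Nothing at hand bears on the cause of this difference.

From the compounds shown here alone, whether a still longer chain carries the numbers further the same way stays open. So does the effect of an amine or a carboxylic acid in place of the phenyl on this chain.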